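The source may report more compounds than this note shows. Statements on the series, on what has been measured and on what is new or still open speak of the compounds shown alone.

Of the compounds shown here, two of a shared core have been measured in an assay on isolated protein for inhibition of extracellular serine/threonine protein kinase FAM20C (Homo sapiens), read by malachite green, tested at 10 uM, in the presence of a further agent that is not named here; on this read-out lower numbers stand for less inhibition and higher numbers for more inhibition at the one concentration tested (going by the name of the read-out). Compound 1 `COc1cc(C)cc(Cl)c1S(=O)(=O)Nc1ccc(Nc2nc(C)cc(Nc3ccc(F)cc3)n2)cc1` gives 12% in this assay. Compound 2 `COc1ccc(Nc2cc(C)nc(Nc3ccc(NS(=O)(=O)c4ccccc4Cl)cc3)n2)cc1` gives 40%, the higher of the two numbers, and the gap to compound 1 lies beyond the usual scatter. The two differ in more than one place, so no single structural change can be tied to that gap.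

Compound 3 `COc1ccc(Nc2cc(C)nc(Nc3ccc(NS(=O)(=O)c4c(Cl)cc(C)cc4OC)cc3)n2)cc1` is not yet measured. It keeps everything in compound 2 except one group: 2-chloro-6-methoxy-4-methylphenyl in place of 2-chlorophenyl on a sulfonyl sulfur. The group that enters in compound 3 is the same one that compound 1 carries on its sulfonyl sulfur, but compound 1 differs from compound 3 elsewhere as well, so its lower value is only a loose hint.

Among the measured compounds shown here, with no measured step to lean on, the expectation for this assay is a small step from compound 2 to compound 3, if any, roughly a number 10 percentage points lower from compound 2 to compound 3 (within the scatter), most likely within or just at the edge of the scatter and leaning downward. Compound 3 is therefore estimated to give 30% in this assay, with a plausible range from 8% to 55%.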

Compound 3, a percentage reported as inhibition, at one concentration (the size of the read-out at that concentration, not a potency): 12%
Estimate against measurement, compound 3: 18 percentage points above; the measured number falls inside the stated range.
By their numbers in this assay, from the lowest: compounds 1 and 3 (each within the scatter of the next); then compound 2.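

In this assay, replacing 2-chlorophenyl with 2-chloro-6-methoxy-4-methylphenyl on a sulfonyl sulfur, with the rest of the molecule unchanged, gives a number 28 percentage points lower from compound 2 to compound 3 (beyond the scatter), the first evidence tied to one place that the group on this sulfur can change the read-out. Among the compounds shown here, with 2-chloro-6-methoxy-4-methylphenyl in place, methoxy in place of fluoro on an aromatic carbon gives no change at the digits printed from compound 1 to compound 3 (within the scatter), so of these two single changes only the one on the sulfonyl sulfur moves the number beyond the scatter. Nothing available explains why the number falls at this position.

The entering group brings a methoxy and a methyl together, so the compounds shown cannot separate the share of each in the step, or say whether an amine or a carboxylic acid in place of the methoxy would behave differently. They also leave open whether exchanging methoxy and fluoro would remain without effect when 2-chlorophenyl sits on the sulfonyl sulfur, since that exchange has been read only alongside the larger group.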